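A few compounds are considered here, and "the series" means these few. Any claim that something is new, unique, unknown or untested is made for them only; others in the source may bear on it.

Values measured so far in a physicochemical assay for solubility, read by HPLC, in phosphate buffer, with a stated time of 24 h, at pH 7.4, tested at 100 uM; on this read-out higher numbers stand for higher solubility and lower numbers for lower solubility
- Compound 1 `O=C(CCCCCNc1c(Nc2ccccc2)c(=O)c1=O)NO` gives 47000000 nM
- Compound 2 `C[C@H](Nc1c(NCCCCCC(=O)NO)c(=O)c1=O)c1ccccc1` gives 73000000 nM

Going by the values given here, compound 2 cannot be set apart from the only other measured compound: the record gives a 1.6-fold higher number from compound 1 to compound 2 (0.19 log units; within the scatter) and no more. The next compound is compound 3 `Cc1ccccc1Nc1c(NCCCCCC(=O)NO)c(=O)c1=O`, which differs from compound 2 on a nitrogen on an aromatic ring, with 2-methylphenyl in place of 1-phenylethyl. The count of that exchange reads (2-methylphenyl in place of 1-phenylethyl on a nitrogen on an aromatic ring). Among the compounds with values here, only one measured step bears on this nitrogen, and it is the same step, a 1.6-fold higher number from compound 1 to compound 2 (0.19 log units; within the scatter), where phenyl gave way to 1-phenylethyl. On that evidence no step beyond the scatter is expected in this assay, and no direction can be relied on. Within the data shown here, no measured compound carries a methyl on that ring, so the range is kept wide. The middle is placed nearer compound 1 at 47000000 nM, whose phenyl is the closer match to 2-methylphenyl. The step expected is a 1.3-fold lower number from compound 2 to compound 3 (0.12 log units; within the scatter). For compound 3 the estimated value is 55000000 nM, with an expected range from 28000000 nM to 95000000 nM.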

Compound 3, solubility: 89000000 nM
Estimate against measurement, compound 3: 1.6-fold (0.21 log units) below, and the stated range covers the measured number.
By their numbers in this assay, from the lowest: compounds 1, 2 and 3 (each within the scatter of the next).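

In this assay, going by these compounds alone, the exchange of 1-phenylethyl for 2-methylphenyl on a nitrogen on an aromatic ring gives a 1.2-fold higher number from compound 2 to compound 3 (0.09 log units; within the scatter) and stands as the first measured change that removes a defined stereocentre from this group. Within the data shown here, the methyl in place of hydrogen on an aromatic carbon gives a 1.9-fold higher number from compound 1 to compound 3 (0.28 log units; within the scatter) and is the first measured substitution on the ring itself. Neither step, nor the earlier one from phenyl to 1-phenylethyl, separates these compounds in this read-out, so the three substituents tried on this nitrogen cannot be told apart, and no information exists that would account for the numbers.

All three compounds carry an aromatic ring of carbon only in this group, which leaves open whether a group of another kind on this nitrogen, such as a saturated ring or a longer chain, would give a step beyond the scatter. As far as these compounds go, it is equally open whether an amine or a carboxylic acid on the aromatic ring would do so, and whether the other stereoisomer of compound 2 would match it.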